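The source may report more compounds than this note shows. Statements on the series, on what has been measured and on what is new or still open speak of the compounds shown alone.

Within the data shown here, compound 1 `COc1cccc(Sc2c(/C=C/[C@@H]3C[C@@H](O)CC(=O)O3)cnc3cc(Cl)c(F)cc23)c1` is one of two compounds measured in an assay (strain Holtzman-Sprague-Dawley) for inhibition of 3-hydroxy-3-methylglutaryl-coenzyme A reductase (Rattus norvegicus), with a stated time of 30 min; on this read-out higher numbers stand for weaker inhibition and lower numbers for stronger inhibition. In this assay compound 1 gives 9240 nM, and compound 2 `O=C1C[C@H](O)C[C@@H](/C=C/c2cnc3c(F)c(F)c(F)cc3c2Sc2ccc(F)cc2)O1` gives 7930 nM; the two numbers lie within the usual scatter of each other, so neither can be called stronger. Compound 3 `COc1cccc(Sc2cc3ncc(/C=C/[C@@H]4C[C@@H](O)CC(=O)O4)c(Sc4cccc(OC)c4)c3cc2F)c1` is not yet measured; it carries (3-methoxyphenyl)sulfanyl in place of chloro on an aromatic carbon, in words: (3-methoxyphenyl)sulfanyl in place of chloro on an aromatic carbon. Among the measured compounds shown here, no measured pair shows this change. From compound 1 the step is expected to be a 1.6-fold higher number from compound 1 to compound 3 (0.21 log units; within the scatter), toward weaker inhibition. Compound 3 is thus estimated at 15000 nM, within a range from 5000 nM to 50000 nM.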

Compound 3, half-maximal inhibitory concentration: 3640 nM
Compound 3: middle estimate off by 4.1-fold (0.61 log units), on the high side; the whole stated range lies above it.
By their numbers in this assay, from the lowest: compound 3; then compounds 2 and 1 (each within the scatter of the next).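

In this assay, (3-methoxyphenyl)sulfanyl in place of chloro gives a 2.5-fold lower number from compound 1 to compound 3 (0.40 log units; beyond the scatter) and so moves the number beyond the scatter. This aromatic carbon therefore tolerates a group of 9 heavy atoms with its own ring in place of a single atom, and inhibition is modestly stronger rather than lost. Nothing available explains this step. On these data alone, it remains open whether the methoxy group, the sulfur link or the added ring matters most. This single step also cannot say how an amine or a carboxylic acid would behave on this carbon.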